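The source may hold more compounds than are shown below. What is called first, only, known or untested is meant among the compounds shown, and "the series" means these compounds.

Compound 1 `C[C@@H](Cn1c(=O)[nH]/c(=N\c2ccc(Oc3nccs3)cc2)n(Cc2ccc(Cl)cc2)c1=O)C(=O)O` was taken through an ADME assay on the whole organism (Rattus norvegicus) for pharmacokinetics, using cassette dosing, at a dose of 1 mg/kg by the oral route (on this read-out lower numbers stand for lower oral bioavailability and higher numbers for higher oral bioavailability), and gave 41.4%. Of the two compounds with a result on this read-out, compound 1 stands lowest: the other is compound 2 `CC(C)Oc1ccc(/N=c2\[nH]c(=O)n(CC(C)(C)C(=O)O)c(=O)n2Cc2ccc(Cl)cc2)cc1Cl`, which in this assay gives 85.3%, a number that lies beyond the usual scatter above compound 1. Compound 2 differs from compound 1 in several places at once, so its value shows only that far higher oral bioavailability is reachable within this series, not which change carries it.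

Compound 3 `C[C@@H](Cn1c(=O)[nH]/c(=N\c2ccc(Oc3cccc(F)n3)cc2)n(Cc2ccc(Cl)cc2)c1=O)C(=O)O` is the untested partner of compound 1. It carries a single change: 6-fluoropyridin-2-yl in place of 1,3-thiazol-2-yl on an oxygen on an aromatic ring. Within the data shown here, no measured pair in this set shows the same change, so what follows rests on compound 1 alone. The step is expected to be small, with no clear direction beyond the scatter, as a number 6.6 percentage points higher from compound 1 to compound 3 (within the scatter). For compound 3 the expected value in this assay is 48%, with a range from 25% to 75%.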

Compound 3, oral bioavailability: 60%
The estimate for compound 3 lay 12 percentage points below the measured number; measured number inside the range.
By their numbers in this assay, from the lowest: compound 1; then compound 3; then compound 2.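

In this assay, putting 6-fluoropyridin-2-yl in place of 1,3-thiazol-2-yl on the oxygen gave a number 18.6 percentage points higher from compound 1 to compound 3 (beyond the scatter) with the rest of the molecule unchanged. Among these compounds, this is the first change in a single place that can be read, and it shows that the group on this oxygen alone can move the read-out beyond the scatter. The five-membered ring of compound 1 is therefore not needed to hold the value at this level, since the six-membered ring of compound 3 ends higher.

This single step cannot separate the change of ring from the fluorine, a question on which a plain pyridin-2-yl or a 6-methoxypyridin-2-yl on the same oxygen would bear. Nothing at hand says what lies behind the step.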